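Swapping a Chlorothiazole Sulfonyl for an Ethylphenyl Sulfonyl

The compounds below may be only part of what the source reports. "The series", "measured", "known", "first", "only" and "open" are said of these compounds alone.

Compound 1 `CC1CCN(C2CCN(S(=O)(=O)c3cnc(Cl)s3)CC2)CC1`: 1800 nM
Compound 2 `C#CCCC(=O)CC1CCN(C2CCN(S(=O)(=O)c3c(C)cc(C)cc3C)CC2)CC1`: 3 nM

Of the compounds shown here, two have so far been measured in a functional assay on DLD-1 cells (Homo sapiens) for antiproliferative activity, read by CellTiter-Glo, with a stated time of 72 h; a higher number here means a weaker inhibitor, a lower number a stronger inhibitor. Compound 1 gives 1800 nM, the highest of the two numbers, so it is the weaker inhibitor of the pair. Compound 2 gives 3 nM, a far lower number, well beyond the scatter. Compound 2 differs from compound 1 in more than one place, so its value alone does not show which change matters most.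

Compound 3 `CCc1ccc(S(=O)(=O)N2CCC(N3CCC(C)CC3)CC2)cc1` is not yet measured. It differs from compound 1 in a single place: 4-ethylphenyl in place of 2-chloro-1,3-thiazol-5-yl on a sulfonyl sulfur. Among the compounds with values here, no single-change step between measured compounds anchors this change. A weak hint comes from compound 2, which lacks the 2-chloro-1,3-thiazol-5-yl group and gives 3 nM, though it also differs elsewhere. A modest step towards a lower number is expected, possibly within the scatter. Compound 3 is therefore estimated at 600 nM, with a range from 120 nM to 3000 nM. That corresponds to an expected step of a 3.0-fold lower number from compound 1 to compound 3 (0.48 log units; beyond the scatter).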

Compound 3, half-maximal inhibitory concentration: > 5000 nM
Compound 3 was reported as a limit; the forecaster's own chance of this, stated with the estimate: 5%; at least 8.3-fold (0.92 log units) between middle value and limit.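

Within the data shown here, this is the first single-change comparison at the sulfonyl sulfur: with the rest of the molecule kept, 4-ethylphenyl in place of 2-chloro-1,3-thiazol-5-yl gives, in this assay, an at least 2.7-fold higher number from compound 1 to compound 3 (0.44 log units; beyond the scatter). So losing the 2-chloro-1,3-thiazol-5-yl group does not by itself lower the number, and this position does not accept just any aromatic ring. Compound 3 gives > 5000 nM, which is a limit of the assay and not a number, so the full size of the step cannot be read, because the value stops at this limit: the limit of > 5000 nM in this assay, at which 1 of the 3 values shown sits.

On these data alone, whether a plain phenyl or a pyridine ring on the sulfonyl sulfur would fare better stays open. So does which of its several differences gives compound 2 its value of 3 nM.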